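Swapping the lactam side group on compound 1

This account rests on a few compounds, and the source may have more. Where it says the series, first, only, none or still open, it means among the compounds named here.

Measured in an ADME assay on the whole organism (plasma) for pharmacokinetics, with Rattus norvegicus as the target, with a stated time of 6 h, at a dose of 10 mg/kg by the oral route; on this read-out lower numbers stand for lower exposure and higher numbers for higher exposure at the dose given
- compound 1 `C=CCNC(=O)C(=O)[C@@H]1CCCCCCCCC[C@H](NC(=O)N[C@H](CN2CCC(C)(C)CC2=O)C(C)(C)C)C(=O)N2C[C@@H]3[C@H]([C@H]2C(=O)N1)C3(C)C` gives 1070 ng.h/mL
- compound 2 `CN(C[C@@H](NC(=O)N[C@H]1CCCCCCCCC[C@@H](C(=O)C(=O)NCC2CC2)NC(=O)[C@@H]2[C@H]3[C@@H](CN2C1=O)C3(C)C)C(C)(C)C)S(=O)(=O)c1cccs1` gives 311 ng.h/mL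
- compound 3 `C=CCNC(=O)C(=O)[C@@H]1CCCCCCCCC[C@H](NC(=O)N[C@H](CN(C)S(=O)(=O)c2cccs2)C(C)(C)C)C(=O)N2C[C@@H]3[C@H]([C@H]2C(=O)N1)C3(C)C` gives 961 ng.h/mL

Compound 1 stands at the top of these numbers, level within the scatter with compound 3, while compound 2 gives a clearly lower number. Compound 4 `C=CCNC(=O)C(=O)[C@@H]1CCCCCCCCC[C@H](NC(=O)N[C@H](CN2C(=O)c3ccccc3C2=O)C(C)(C)C)C(=O)N2C[C@@H]3[C@H]([C@H]2C(=O)N1)C3(C)C` keeps the core and the vinyl of compound 1 but loses 4,4-dimethyl-2-oxopiperidin-1-yl, on a saturated chain carbon, two bonds along the chain from an amide-type nitrogen (a group of 11 heavy atoms (8 carbon, 1 nitrogen, 2 oxygen; one five-membered non-aromatic ring with 1 hetero atom, one six-membered aromatic ring of carbon only) in place of a group of 9 heavy atoms (7 carbon, 1 nitrogen, 1 oxygen; one six-membered non-aromatic ring with 1 hetero atom), on a saturated chain carbon, two bonds along the chain from an amide-type nitrogen). Among the measured compounds shown here, one measured step touches that place, the change to compound 3 (a 1.1-fold lower number from compound 1 to compound 3 (0.05 log units; within the scatter)). The other step (a 3.1-fold higher number from compound 2 to compound 3 (0.49 log units; beyond the scatter)) is vinyl in place of cyclopropyl, a change not made here, so it carries no weight. For the measured compounds named here, the entering group itself has no measurement, so the single step at this place is thin support. The expected change is small and slightly downward, not beyond the scatter (a 1.3-fold lower number from compound 1 to compound 4 (0.13 log units; within the scatter)). Compound 4 is estimated at 800 ng.h/mL with 320 ng.h/mL to 1800 ng.h/mL as the expected range.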

Compound 4, area under the concentration-time curve: 880 ng.h/mL
For compound 4 the middle estimate is 1.1-fold (0.04 log units) below the measured one, within the range that was stated.
By their numbers in this assay, from the lowest: compound 2; then compounds 4, 3 and 1 (each within the scatter of the next).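

In this assay, a third group on a saturated chain carbon, two bonds along the chain from an amide-type nitrogen, leaves the number level (a 1.2-fold lower number from compound 1 to compound 4 (0.08 log units; within the scatter); a 1.1-fold lower number from compound 3 to compound 4 (0.04 log units; within the scatter)). The group entering in compound 4, with its five-membered non-aromatic ring and six-membered aromatic ring of carbon only, therefore stands level with both 4,4-dimethyl-2-oxopiperidin-1-yl and methyl((thiophen-2-yl)sulfonyl)amino, so compounds 1, 3 and 4 show no separation by ring type or heavy-atom count. Nothing at hand gives a reason for this flat result.

Open, from the compounds shown here alone, is whether a primary amine or a carboxylic acid on this carbon would stay level with these three groups. Also open, going by these compounds, is whether cyclopropyl for vinyl would give a step like (a 3.1-fold higher number from compound 2 to compound 3 (0.49 log units; beyond the scatter)) with the group of compound 4 in place.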